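Series notes: chain-end aryl change from compound 3

The compounds below may be only part of what the source reports. "The series", "measured", "known", "first", "only" and "open" are said of these compounds alone.

Compound 3 `Fc1ccc(-c2ccc3c(NCCCNCc4ccco4)ccnc3c2)cc1` stands second highest of the three numbers in an ADME assay on HepG2 cells (Homo sapiens) for cytotoxicity, read by luminescence, CellTiter-Glo and ATP content, with a stated time of 72 h (a higher number here means that more compound is needed for the effect, a lower number that less compound is needed), where compound 3 gives 7760 nM; compound 1 `COc1ccccc1Oc1ccc2c(NCCCNCc3ccco3)ccnc2c1` gives 6500 nM and compound 2 `c1ccc(Oc2ccc3c(NCCCNCc4ccco4)ccnc3c2)cc1` gives 15200 nM. The measured steps all sit on an aromatic carbon of the shared core: a 2.3-fold higher number from compound 1 to compound 2 (0.37 log units; beyond the scatter), a 1.2-fold higher number from compound 1 to compound 3 (0.08 log units; within the scatter) and a 2.0-fold lower number from compound 2 to compound 3 (0.29 log units; within the scatter). Only the first of these is beyond the scatter, and it is modest. Compound 4 `COc1ccc(F)cc1CNCCCNc1ccnc2cc(-c3ccc(F)cc3)ccc12` differs from compound 3 on a saturated chain carbon bound to an amine nitrogen: 5-fluoro-2-methoxyphenyl in place of furan-2-yl on a saturated chain carbon bound to an amine nitrogen. Going by the values given here, no measured step touches that position, so none bears directly on this change; the only guide is that every change seen so far on this core moved this assay little. The expected step is therefore a 1.0-fold higher number from compound 3 to compound 4 (0.01 log units; within the scatter), within or at the edge of the scatter, in no firm direction. The estimate for compound 4 in this assay is 8000 nM, with a range from 3000 nM to 22000 nM.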

Compound 4, half-maximal effective concentration: 770 nM
Beside the measured number, compound 4's estimate is 10-fold (1.02 log units) above it; the measured number lies below the stated range.
By their numbers in this assay, from the lowest: compound 4; then compounds 1, 3 and 2 (each within the scatter of the next, the first and the last beyond it).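

On a saturated chain carbon bound to an amine nitrogen, 5-fluoro-2-methoxyphenyl in place of furan-2-yl gives a 10-fold lower number from compound 3 to compound 4 (1.00 log units; beyond the scatter), a larger step in this assay than any of the three seen on an aromatic carbon of the shared core. The chain end is therefore a position at which this read-out responds, and the small movement seen so far holds only for the aromatic-carbon changes among compounds 1, 2 and 3. No supporting measurement is available to account for the step.

The change swaps the ring and adds methoxy and fluorine together, leaving the share of each part open. A plain benzyl, a 2-methoxybenzyl or a 5-fluorobenzyl at the chain end would separate these parts, and a longer chain would test whether the step persists.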